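Working notes: thiophen-2-yl in place of 4-chlorophenyl

The source may report more compounds than this note shows. Statements on the series, on what has been measured and on what is new or still open speak of the compounds shown alone.

Measured in an ADME assay on CCRF-CEM cells (Homo sapiens) for antiproliferative activity, with a stated time of 48 h; on this read-out lower numbers stand for stronger inhibition and higher numbers for weaker inhibition:
- compound 1 `C=C(Br)C(=O)Nc1ccc(/C=C/C(=O)c2ccc(F)cc2)cc1`: 1100 nM
- compound 2 `C=C(Br)C(=O)Nc1ccc(/C=C/C(=O)c2ccc(Cl)cc2)cc1`: 950 nM
- compound 3 `C=C(Br)C(=O)Nc1ccc(/C=C/C(=O)c2ccc(Cl)c(Cl)c2)cc1`: 1700 nM

Compound 2, at 950 nM, stands within the scatter of both other compounds, so the three numbers give no reliable order. The next compound to be measured is compound 4 `C=C(Br)C(=O)Nc1ccc(/C=C/C(=O)c2cccs2)cc1`. It differs from compound 2 by thiophen-2-yl in place of 4-chlorophenyl on a carbonyl carbon.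

For the measured compounds named here, three measured steps bear on this change, since each alters only the group on the carbonyl carbon or its substituents: a 1.2-fold lower number from compound 1 to compound 2 (0.06 log units; within the scatter), a 1.8-fold higher number from compound 2 to compound 3 (0.25 log units; within the scatter) and a 1.5-fold higher number from compound 1 to compound 3 (0.19 log units; within the scatter). None of them exceeds the scatter, so these changes have so far left this assay essentially flat. Going by the values given here, no measured compound carries thiophen-2-yl, however, and this swap replaces the whole group rather than one substituent. The evidence therefore supports no expected direction and no expected step beyond the scatter, though the uncertainty is wider than the measured steps alone suggest. The expected change is a 1.1-fold higher number from compound 2 to compound 4 (0.02 log units; within the scatter). For compound 4 the estimated value is 1000 nM, with an expected range of 420 nM to 2400 nM.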

Compound 4, half-maximal inhibitory concentration: 730 nM
Beside the measured number, compound 4's estimate is 1.4-fold (0.14 log units) above it, and the stated range covers the measured number.
By their numbers in this assay, from the lowest: compounds 4, 2, 1 and 3 (each within the scatter of the next, the first and the last beyond it).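

Notes on the group on the carbonyl carbon: in this assay this position accepts a change of the whole aromatic ring and not only of its substituents, as thiophen-2-yl in place of 4-chlorophenyl gives a 1.3-fold lower number from compound 2 to compound 4 (0.11 log units; within the scatter) and thiophen-2-yl in place of 4-fluorophenyl gives a 1.5-fold lower number from compound 1 to compound 4 (0.18 log units; within the scatter), so a five-membered aromatic ring with a sulfur atom stays level with both monohalogenated phenyl groups. Thiophen-2-yl in place of 3,4-dichlorophenyl gives a 2.3-fold lower number from compound 3 to compound 4 (0.37 log units; beyond the scatter), the first step in the series beyond the scatter, though only a modest one, and it separates the two ends of a range whose other steps all stay within the scatter. Nothing measured here accounts for these numbers.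

Still open, on these data alone, is whether the flat picture holds for other groups on the carbonyl carbon, such as furan-2-yl, pyridin-3-yl or a saturated cyclohexyl ring, or for a thiophen-2-yl carrying a chloro or an amine substituent. Also open, as far as these compounds go, is whether a group with a carboxylic acid on the ring would move the number further than any step seen so far.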